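Swapping the Amide Aryl Group on the Shared Core

The source may hold more compounds than are shown below. What is called first, only, known or untested is meant among the compounds shown, and "the series" means these compounds.

Measured compounds:
compound 1 `Cc1cccc(Cl)c1NC(=O)CN1CCN(c2nnc(Cc3ccncc3)c3ccccc23)CC1`: 22600 nM
compound 2 `O=C(CN1CCN(c2nnc(Cc3ccncc3)c3ccccc23)CC1)Nc1cccc(F)c1`: 6130 nM
compound 3 `Cc1ccc(NC(=O)CN2CCN(c3nnc(Cc4ccccc4)c4ccccc34)CC2)c(C)c1`: "not active" (no number reported)

In a functional assay on HT-29 cells (Homo sapiens) for cytotoxicity, read by MTT assay, with a stated time of 72 h (a higher number here means a weaker inhibitor, a lower number a stronger inhibitor), compound 3 gives "not active" (no number reported), so no number places it among the measured compounds. Compound 4 `O=C(CN1CCN(c2nnc(Cc3ccccc3)c3ccccc23)CC1)Nc1cccc(Br)c1` differs from compound 3 by 3-bromophenyl in place of 2,4-dimethylphenyl on an amide-type nitrogen. Among the measured compounds shown here, the only measured step of a similar kind on the shared core is a 3.7-fold lower number from compound 1 to compound 2 (0.57 log units; beyond the scatter), where a phenyl bearing two groups gave way to a phenyl bearing a single halogen and the number fell modestly. Compound 3 offers no starting number to anchor such a step, so the expectation is a weak inhibitor at best, with a fair chance of another report without a number. Compound 4 is estimated at 25000 nM, expected between 6000 nM and 100000 nM.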

Compound 4, half-maximal inhibitory concentration: 13400 nM
Estimate against measurement, compound 4: 1.9-fold (0.27 log units) above; low and high end bracket the measured number.
By their numbers in this assay, from the lowest: compound 2; then compounds 4 and 1 (each within the scatter of the next).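

Compound 3 is reported as "not active" without a number in this assay, so the step to compound 4, at 13400 nM, cannot be read. On these data alone, what 3-bromophenyl in place of 2,4-dimethylphenyl does to the number stays open, and no evidence here bears on the result.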